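A Cyclopropyl for a Methyl at the Limit

A few compounds are considered here, and "the series" means these few. Any claim that something is new, unique, unknown or untested is made for them only; others in the source may bear on it.

Measured compounds:
Compound 1 `CCCc1nc(C)c2cnn(CC)c(=O)n12` gives > 48000 nM in a functional assay for inhibition, with Homo sapiens as the target (a higher number here means a weaker inhibitor, a lower number a stronger inhibitor), which is a limit of the assay rather than a number.
Compound 2 `CSc1nnc(-c2ccccc2)c2cncn12` gives > 48000 nM in this assay, also a limit.
Compound 3 `CCCc1nc(C)c2c(C)nn(CC)c(=O)n12` gives > 48000 nM in this assay, again a limit.

Compound 1 therefore stands only at a limit, and no number is known for it; the same holds for the other two compounds, as the limit of > 48000 nM in this assay, at which 3 of the 3 values shown sit, shows. For the measured compounds named here, the single measured step that changes one place, a step that the two limits leave unreadable from compound 1 to compound 3, is unreadable: both of its ends are limits.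

Compound 4 `CCCc1nc(C)c2cnn(CC3CC3)c(=O)n12` differs from compound 1 by cyclopropyl in place of methyl on a saturated chain carbon bound to an aromatic nitrogen. Going by the values given here, no measured step bears on this change, so there is no basis for expecting a step in this assay in either direction beyond the scatter. Among the compounds with values here, compound 4 is therefore expected to sit where compound 1 sits, most likely again at the limit, with a step that the limit leaves unreadable from compound 1 to compound 4 expected to be no real step. The estimate for compound 4 is 70000 nM, ranging from 20000 nM to 250000 nM.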

Compound 4, half-maximal inhibitory concentration: > 48000 nM
Compound 4 was reported as a limit; the forecaster's own chance of this, stated with the estimate: 85%; the middle value lies beyond the limit too.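

Compound 1 and compound 4 both stand at a limit rather than a number, so the swap of methyl for cyclopropyl gives no readable step: the limit of > 48000 nM in this assay, at which 4 of the 4 values shown sit. The compounds shown leave open how strong each one truly is, and which change to the shared core, if any, would yield a measurable number.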